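The source may report more compounds than this note shows. Statements on the series, on what has been measured and on what is new or still open speak of the compounds shown alone.

Measured compounds:
- compound 1 `COc1cc(-c2nnc3n2NC(c2ccco2)C(C(=O)c2ccc(-c4ccccc4)cc2)S3)cc(OC)c1OC` gives 45900 nM in a functional assay on PC-3 cells (Homo sapiens) for cytotoxicity, read by MTT assay, with a stated time of 48 h; on this read-out lower numbers stand for stronger inhibition and higher numbers for weaker inhibition
- compound 2 `COc1cc(-c2nnc3n2NC(c2ccco2)C(C(=O)c2ccc(Cl)cc2)S3)cc(OC)c1OC` gives 67800 nM in this assay
- compound 3 `COc1cc(-c2nnc3n2NC(c2ccco2)C(C(=O)c2ccccc2)S3)cc(OC)c1OC` gives 64300 nM in this assay

Among these three numbers, compound 3 stands second highest, and all three lie within the scatter of one another: the step of a 1.4-fold higher number from compound 1 to compound 3 (0.15 log units; within the scatter) and the step of a 1.1-fold lower number from compound 2 to compound 3 (0.02 log units; within the scatter) both stay inside it, as does the step of a 1.5-fold higher number from compound 1 to compound 2 (0.17 log units; within the scatter). Whatever is placed on the aromatic carbon para to a large group, whether phenyl, chloro or hydrogen, has so far left the number where it was.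

Compound 4 `COc1cc(-c2nnc3n2NC(c2ccco2)C(C(=O)c2ccc(F)cc2)S3)cc(OC)c1OC` differs from compound 3 by fluoro in place of hydrogen on an aromatic carbon. For the measured compounds named here, the steps that bear on this are exactly those three, all of them changes at the same aromatic carbon and all within the scatter. On that basis no step beyond the scatter is expected in this assay for compound 4, in either direction; the expected step is a 1.0-fold lower number from compound 3 to compound 4 (0.02 log units; within the scatter). Compound 4 is therefore estimated at 62000 nM, with a range from 30000 nM to 125000 nM.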

Compound 4, half-maximal inhibitory concentration: 27700 nM
Estimate against measurement, compound 4: 2.2-fold (0.35 log units) above; measured number below the stated range.
By their numbers in this assay, from the lowest: compounds 4, 1, 3 and 2 (each within the scatter of the next, the first and the last beyond it).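

For the compounds shown here, at the aromatic carbon where phenyl, chloro and hydrogen had left the number in place, fluoro is the first group to produce a step beyond the scatter in this assay, with a 2.3-fold lower number from compound 3 to compound 4 (0.37 log units; beyond the scatter) and a 2.4-fold lower number from compound 2 to compound 4 (0.39 log units; beyond the scatter), both modest. The position therefore does respond to a change, yet the response does not separate fluoro from every other group, since a 1.7-fold lower number from compound 1 to compound 4 (0.22 log units; within the scatter) stays within the scatter, and compound 4 and compound 1 cannot be told apart here. Nothing offered here gives a reason for these steps.

The compounds shown leave open whether a methoxy group, an amine or a carboxylic acid on this carbon would fall with fluoro and phenyl or with chloro and hydrogen in this assay. They also leave open whether fluoro gives a similar step on another carbon of the same six-membered aromatic ring.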